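A few compounds are considered here, and "the series" means these few. Any claim that something is new, unique, unknown or untested is made for them only; others in the source may bear on it.

Among the measured compounds shown here, in a functional assay on NCI/ADR-RES cells (Homo sapiens) for antiproliferative activity, read by sulforhodamine B assay, with a stated time of 48 h (a lower number here means a stronger inhibitor, a higher number a weaker inhibitor), compound 1 (`O=C(NCCCNc1cc(-c2cn(-c3ccccc3)nc2-c2cccc(O)c2)ccn1)Nc1ccc(F)cc1`) gives 3510 nM and compound 2 (`O=C(NCCCNc1cc(-c2cn(-c3ccccc3)nc2-c2cccc(O)c2)ccn1)Nc1cccc(C(F)(F)F)c1`) gives 4900 nM, so compound 1 stands level, within the scatter, with the only other compound measured. Compound 3 (`COc1cccc(-c2nn(-c3ccccc3)cc2-c2ccnc(NCCCNC(=O)Nc3ccc(F)cc3)c2)c1`) differs from compound 1 in one place: methyl in place of hydrogen on an oxygen on an aromatic ring. This is methyl in place of hydrogen on an oxygen on an aromatic ring, or 3-hydroxyphenyl to 3-methoxyphenyl. For the measured compounds named here, the single measured step, a 1.4-fold higher number from compound 1 to compound 2 (0.14 log units; within the scatter), concerns a different place, the aryl group on an amide-type nitrogen, and it bears on this change only indirectly. Going by the values given here, no measured pair tests the hydroxy group itself, so no step beyond the scatter is expected in this assay, in either direction, though with wide uncertainty. The expected step is a 1.1-fold higher number from compound 1 to compound 3 (0.06 log units; within the scatter). For compound 3 the estimated value is 4000 nM, with an expected range of 1500 nM to 11000 nM.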

Compound 3, half-maximal inhibitory concentration: 7290 nM
The estimate for compound 3 lay 1.8-fold (0.26 log units) below the measured number, and the stated range covers the measured number.
By their numbers in this assay, from the lowest: compounds 1, 2 and 3 (each within the scatter of the next, the first and the last beyond it).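

Among the compounds shown here, compound 3 gives the first measured reading on the hydroxy group itself in this assay: methyl in place of hydrogen on this oxygen produces a 2.1-fold higher number from compound 1 to compound 3 (0.32 log units; beyond the scatter) and so moves the number towards a weaker inhibitor, by a modest step. The step from 3-hydroxyphenyl to 3-methoxyphenyl therefore registers where the earlier change on the amide-type nitrogen stayed within the scatter, yet activity is not lost, since compound 3 still gives 7290 nM in this assay. No measurement at hand bears on the reason for this step.

On these data alone, it remains open whether a longer chain on this oxygen, such as ethoxy, or an amine or fluorine in place of the hydroxy would move the number further. As far as these compounds go, it also remains open whether the methoxy step would hold with the 3-(trifluoromethyl)phenyl group of compound 2.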